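The source may report more compounds than this note shows. Statements on the series, on what has been measured and on what is new or still open speak of the compounds shown alone.

Within the data shown here, compound 2 `CC(c1ccc(OCc2c(-c3c(Cl)cccc3Cl)noc2C2CC2)nc1C(F)(F)F)N(C)c1ccc(C(=O)O)cc1` gives 182 nM in a functional assay on HEK293 cells for agonist activity at Bile acid receptor (Homo sapiens), read by a luciferase reporter (on this read-out higher numbers stand for an effect only at larger amounts of compound and lower numbers for an effect already at smaller amounts), the lowest of the two numbers so far. Compound 1 `CC(Nc1ccc(C(=O)O)cc1)c1ccc(OCc2c(-c3c(Cl)cccc3Cl)noc2C2CC2)nc1C(F)(F)F` gives 202 nM. Among the measured compounds shown here, the one recorded step, a 1.1-fold lower number from compound 1 to compound 2 (0.05 log units; within the scatter), lies within the scatter, so neither compound stands apart. Compound 3 `CC(Oc1ccc(C(=O)O)cc1)c1ccc(OCc2c(-c3c(Cl)cccc3Cl)noc2C2CC2)nc1C(F)(F)F` carries 4-carboxyphenoxy in place of (4-carboxyphenyl)(methyl)amino on a saturated chain carbon bound to an aromatic carbon and a saturated chain carbon. No measured step exchanges the linking nitrogen for an oxygen; the only step shown says merely that a methyl on that nitrogen changed little. For compound 3 a step of about a 1.4-fold higher number from compound 2 to compound 3 (0.15 log units; within the scatter) is expected, most likely toward a somewhat higher number, possibly within the scatter. Compound 3 is therefore estimated at 260 nM, with a range from 80 nM to 850 nM.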

Compound 3, half-maximal effective concentration: 611 nM
Compound 3: the middle estimate sits 2.4-fold (0.37 log units) below what was measured, and the stated range covers the measured number.
By their numbers in this assay, from the lowest: compounds 2 and 1 (each within the scatter of the next); then compound 3.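

At this position the atom joining the chain to the 4-carboxyphenyl group matters more than the methyl did. 4-Carboxyphenoxy gives a 3.4-fold higher number from compound 2 to compound 3 (0.53 log units; beyond the scatter) and a 3.0-fold higher number from compound 1 to compound 3 (0.48 log units; beyond the scatter), both beyond the scatter, so the two nitrogen-linked compounds stand together and the oxygen-linked compound 3 stands apart from them. Nothing available here explains this difference. Still open, on these data alone, is where a sulfur or a methylene in that linking place would fall relative to the nitrogen and oxygen links.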